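From hydroxy to nitro on a shared core

A few compounds are considered here, and "the series" means these few. Any claim that something is new, unique, unknown or untested is made for them only; others in the source may bear on it.

Compound 1: `COc1ccc(Cc2cc(OC)c(OC)c(OC)c2)cc1N`, 31 nM
Compound 2: `COc1ccc(Cc2cc(OC)c(OC)c(OC)c2)cc1O`, 28 nM

For the measured compounds named here, in a functional assay on A549 cells (Homo sapiens) for cytotoxicity, read by XTT assay, with a stated time of 72 h (on this read-out higher numbers stand for weaker inhibition and lower numbers for stronger inhibition), compound 2 gives 28 nM, level with its only measured neighbour, compound 1, at 31 nM. Going by the values given here, the single measured step is a 1.1-fold lower number from compound 1 to compound 2 (0.04 log units; within the scatter), with hydroxy in place of amino on an aromatic carbon.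

Compound 3 (`COc1ccc(Cc2cc(OC)c(OC)c(OC)c2)cc1[N+](=O)[O-]`) has nitro in place of hydroxy on an aromatic carbon, ortho to a methoxy group: nitro in place of hydroxy on an aromatic carbon. Among the compounds with values here, no measured compound carries nitro, so a 1.1-fold lower number from compound 1 to compound 2 (0.04 log units; within the scatter) covers a different exchange and cannot fix the size of this one. Nitro brings more heavy atoms than the two groups compared so far. A moderate move towards weaker inhibition is expected in this assay, though this is uncertain. The expected step is a 4.3-fold higher number from compound 2 to compound 3 (0.63 log units; beyond the scatter). For compound 3 the estimated value is 120 nM, with an expected range of 25 nM to 600 nM.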

Compound 3, half-maximal inhibitory concentration: 26 nM
The estimate for compound 3 lay 4.6-fold (0.66 log units) above the measured number; the measured number falls inside the stated range.
By their numbers in this assay, from the lowest: compounds 3, 2 and 1 (each within the scatter of the next).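

In this assay nitro in place of hydroxy gives a 1.1-fold lower number from compound 2 to compound 3 (0.03 log units; within the scatter) and nitro in place of amino gives a 1.2-fold lower number from compound 1 to compound 3 (0.08 log units; within the scatter) on the same shared core. This position, ortho to a methoxy group, has now carried three different groups with no step beyond the scatter, even though nitro has 3 heavy atoms against 1 for hydroxy and 0 hydrogen-bond donors against 1. No measurement shown here explains why the numbers stay level.

The compounds shown leave open whether this tolerance extends to a carboxylic acid or a longer chain at the same position. They also leave open what a plain hydrogen there would give, which would show whether any group is needed at this position at all.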